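From an Ethyl to a Formyl Group on a Shared Core

This account rests on a few compounds, and the source may have more. Where it says the series, first, only, none or still open, it means among the compounds named here.

Of the compounds shown here, two built on the same core have been measured in a functional assay on SR cells (Homo sapiens) for inhibition, read by sulforhodamine B assay, with a stated time of 48 h, tested at 10 uM; on this read-out lower numbers stand for less inhibition and higher numbers for more inhibition at the one concentration tested (going by the name of the read-out). Compound 1 `COc1ccc(-c2cn3ccnc3c(-c3ccc4ncn(C5CCCCC5)c4c3)n2)cc1` gives 91.7% in this assay. Compound 2 `CCc1ccc(-c2cn3ccnc3c(-c3ccc4ncn(Cc5ccccc5)c4c3)n2)cc1` gives 49.9% in this assay. Of these two numbers, compound 2 stands lowest; the nearest number is that of compound 1, which lies higher by a gap beyond the usual scatter. The two compounds differ in more than one place, so no single structural step can be read between them.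

Compound 3 `O=Cc1ccc(-c2cn3ccnc3c(-c3ccc4ncn(Cc5ccccc5)c4c3)n2)cc1` has not yet been measured. It differs from compound 2 in one place: formyl in place of ethyl on an aromatic carbon. Within the data shown here, no measured pair shows this kind of change, so there is no step to lean on. Among the measured compounds shown here, compound 2 gives 49.9%, a number near the middle of the scale, and that is the only anchor for compound 3. The expected step is a number 0.1 percentage points higher from compound 2 to compound 3 (within the scatter), small and likely within the scatter in either direction. Compound 3 is estimated at 50% in this assay, with a range from 25% to 75%.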

Compound 3, a percentage reported as inhibition, at one concentration (the size of the read-out at that concentration, not a potency): 47.5%
Beside the measured number, compound 3's estimate is 2.5 percentage points above it; low and high end bracket the measured number.
By their numbers in this assay, from the lowest: compounds 3 and 2 (each within the scatter of the next); then compound 1.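

Swapping the 4-ethylphenyl for a 4-formylphenyl gives, in this assay, a number 2.4 percentage points lower from compound 2 to compound 3 (within the scatter), and this is the first change in the series that can be read at a single place. At this aromatic carbon, para to a large group, two carbons give way to a carbon and an oxygen, and a double bond outside the aromatic rings and a hydrogen-bond acceptor come in, yet the two numbers cannot be told apart on this read-out. Nothing measured here says why these two groups give such similar numbers, so the result stands as an observation without an explanation.

This single step leaves open whether a quite different group at the same carbon, such as an amine, a carboxylic acid or a longer chain, would also leave the number in this range. From the compounds shown here alone, compound 1 gives 91.7% but carries its own groups at two places of the shared core, so the steps from it to the others cannot be read, and which of those places matters remains unknown.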